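From methoxy to acetoxy on the shared core

The source may report more compounds than this note shows. Statements on the series, on what has been measured and on what is new or still open speak of the compounds shown alone.

Measured in an ADME assay on THP-1 cells (Homo sapiens) for cytotoxicity, read by MTT assay, with a stated time of 72 h; a lower number here means that less compound is tolerated, a higher number that more compound is tolerated
- compound 1 `C=C(C(=O)OCC)C(OCCC(=O)OCC)c1ccccc1Cl` gives > 100 uM
- compound 2 `C=C(C(=O)OCC)C(OC)c1ccccc1Cl` gives > 100 uM

Compound 2 stands at > 100 uM, which is a limit and not a number. Compound 1 stands at a limit too, so the data show only (the limit of > 100 uM in this assay, at which 2 of the 2 values shown sit). Compound 3 `C=C(C(=O)OCC)C(OC(C)=O)c1ccccc1Cl` differs from compound 2 by acetyl in place of methyl on an oxygen on a saturated carbon. Among the compounds with values here, the only measured step is a step that the two limits leave unreadable from compound 1 to compound 2, so it offers no size to carry over. No step beyond the scatter is therefore expected in this assay, although a limit leaves this open. The estimated step is a number no higher from compound 2 to compound 3 (the limit leaves the size open). Compound 3 is expected at 100 uM, with an estimated range from 30 uM to 200 uM.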

Compound 3, half-maximal toxic concentration: 33.3 uM
For compound 3 the middle estimate is 3.0-fold (0.48 log units) above the measured one; the measured number falls inside the stated range.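

Compound 3 is the only one of the three compounds shown that gives a number rather than a limit in this assay; the other two sit at a limit: the limit of > 100 uM in this assay, at which 2 of the 3 values shown sit. On this oxygen, acetyl in place of methyl gives an at least 3.0-fold lower number from compound 2 to compound 3 (0.47 log units; beyond the scatter), and acetyl in place of 2-(ethoxycarbonyl)ethyl gives an at least 3.0-fold lower number from compound 1 to compound 3 (0.47 log units; beyond the scatter). The group on this oxygen can therefore change how much compound the cells tolerate, and both steps are minimum sizes.

Going by these compounds, it remains open whether a longer acyl chain such as butanoyl, or a benzoyl group, on the same oxygen would lower the number as acetyl does. A free hydroxyl there is also untested among the compounds shown.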